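Stereocentre inversion in the weakest amide of the series

The compounds below may be only part of what the source reports. "The series", "measured", "known", "first", "only" and "open" are said of these compounds alone.

In a functional assay on ID8 cells (Mus musculus) for antiproliferative activity (on this read-out higher numbers stand for weaker inhibition and lower numbers for stronger inhibition), compound 1 `O=C(Nc1ccc(O)c2c(=O)cc(-c3ccccc3Cl)oc12)c1ccccc1` gives 13000 nM and compound 2 `O=C(Nc1ccc(O)c2c(=O)cc(-c3ccccc3Cl)oc12)c1ccc(Cl)cc1` gives 5500 nM. Compound 3 `C[C@@H](NC(=O)OC(C)(C)C)C(=O)Nc1ccc(O)c2c(=O)cc(-c3ccccc3Cl)oc12` has the highest number of the three, at 104000 nM. Compound 4 `C[C@H](NC(=O)OC(C)(C)C)C(=O)Nc1ccc(O)c2c(=O)cc(-c3ccccc3Cl)oc12` differs from it as follows: the two compounds have the same atoms and bonds and differ only in configuration as drawn: 1 of 1 stereo elements differ; a stereocentre at a saturated chain carbon is drawn R in compound 3 and S in compound 4.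

The nearest evidence is the entry of 1-((tert-butoxycarbonyl)amino)ethyl, which gave an 8.0-fold higher number from compound 1 to compound 3 (0.90 log units; beyond the scatter) and a 19-fold higher number from compound 2 to compound 3 (1.28 log units; beyond the scatter). The chloro change gave a 2.4-fold lower number from compound 1 to compound 2 (0.37 log units; beyond the scatter). All these steps change atoms, and none tests configuration, so the data give no size for this inversion. No step beyond the scatter is therefore expected in this assay, though the uncertainty is wide in both directions.

The expected change is a 1.2-fold lower number from compound 3 to compound 4 (0.09 log units; within the scatter).

The estimate for compound 4 is 85000 nM, with a range of 30000 nM to 200000 nM.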

Compound 4, half-maximal inhibitory concentration: 9800 nM
For compound 4 the middle estimate is 8.7-fold (0.94 log units) above the measured one; measured number outside the range, below it.
By their numbers in this assay, from the lowest: compounds 2, 4 and 1 (each within the scatter of the next, the first and the last beyond it); then compound 3.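

The stereocentre at the saturated chain carbon is a strong determinant at this position, and the gap can be assigned to configuration alone with an 11-fold lower number from compound 3 to compound 4 (1.03 log units; beyond the scatter), because of this: the fact that compounds 3 and 4 differ only in the configuration as drawn. The 1-((tert-butoxycarbonyl)amino)ethyl group therefore carries no penalty as such. Drawn S, it gives a 1.8-fold higher number from compound 2 to compound 4 (0.25 log units; within the scatter) and a 1.3-fold lower number from compound 1 to compound 4 (0.12 log units; within the scatter), so the earlier loss belongs to the R form of compound 3 alone.

This rests on a single pair of stereoisomers. On these data alone, whether the S preference persists with a free amine in place of the tert-butoxycarbonyl-protected amino group, or with a longer chain in place of the ethyl, remains open.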